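Methyl for Chloro on a Benzyl Ring, Two Cores

This account rests on a few compounds, and the source may have more. Where it says the series, first, only, none or still open, it means among the compounds named here.

Measured compounds:
compound 1, `C=C(Br)C(=O)Nc1cccc(/C=C2\SC(=O)N(Cc3ccc(C)cc3)C2=O)c1`: 1200 nM
compound 2, `C=C(Br)C(=O)Nc1cccc(/C=C2\SC(=O)N(Cc3ccc(Cl)cc3)C2=O)c1`: 2700 nM
compound 3, `Nc1ccc(/C=C2\SC(=O)N(Cc3ccc(Cl)cc3)C2=O)cc1`: 77000 nM

All three were tested in a functional assay on HeLa cells (Homo sapiens) for cytotoxicity, read by cell counting, with a stated time of 4 days; on this read-out higher numbers stand for weaker inhibition and lower numbers for stronger inhibition. Compound 2 and compound 1 share a core and differ only by methyl in place of chloro on an aromatic carbon. Compound 3 rests on a different core; the difference between the two cores is not broken down here, and compound 3 gives the highest number of the three. Compound 4 `Cc1ccc(CN2C(=O)S/C(=C\c3ccc(N)cc3)C2=O)cc1` has not yet been measured. It differs from compound 3 by methyl in place of chloro on an aromatic carbon, the same change at the same place as between compound 2 and compound 1. The step expected is a 2.2-fold lower number from compound 3 to compound 4 (0.34 log units; beyond the scatter), resting on the same change having given a 2.3-fold lower number from compound 2 to compound 1 (0.35 log units; beyond the scatter). Compound 4 is therefore expected to give about 35000 nM, likely between 15000 nM and 90000 nM.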

Compound 4, half-maximal inhibitory concentration: > 250000 nM
Compound 4: no number, only a limit (the forecaster's own chance of this, stated with the estimate: 10%); at least 7.1-fold (0.85 log units) between middle value and limit.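

In this assay, methyl in place of chloro on an aromatic carbon gives an at least 3.2-fold higher number from compound 3 to compound 4 (0.51 log units; beyond the scatter). The value of compound 4, > 250000 nM, is a limit of the assay and not a number, so the full size of this step is not shown. The change therefore does not carry over from one core to the other in the direction or size seen before, although a single pair on each core does not show what sets the two steps apart: the same change on two cores in this assay, a 2.3-fold lower number (0.35 log units; beyond the scatter) from compound 2 to compound 1 and an at least 3.2-fold higher number (0.51 log units; beyond the scatter) from compound 3 to compound 4, at least 7.3-fold (0.86 log units) apart, beyond the scatter of two such steps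

On these data alone, it remains open how a methoxy group or a fluoro group in the same place would behave on each core. Also open, as far as these compounds go, is which part of the difference between the two cores goes with the opposite steps.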